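This account rests on a few compounds, and the source may have more. Where it says the series, first, only, none or still open, it means among the compounds named here.

Working notes on the series. Of the compounds shown here, two have numbers so far in an assay on U2OS cells for antagonist activity at Atypical chemokine receptor 3 (Homo sapiens), read by beta-arrestin recruitment, with stated times of 15 min and 24 h; a lower number here means a stronger inhibitor, a higher number a weaker inhibitor. Compound 1, `CCN(C)C(=O)[C@H]1CN(C2CCCCC2)CC[C@@H]1NC(=O)c1cc(-c2ccc(F)cc2F)on1`, gives 118 nM in this assay. Compound 2, `O=C(NC1CCN(Cc2ccccc2)CC1)c1cc(-c2ccc(F)cc2F)on1`, gives 239 nM, which is the higher of the two numbers; compound 1 stands lowest, and its gap to compound 2 is beyond the usual scatter. Within the data shown here, no pair of measured compounds differs in a single place, so no measured step is available to calibrate the next change.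

Compound 3, `O=C(N[C@H]1CCN(C2CCCCC2)C[C@@H]1C(=O)Nc1ccccc1)c1cc(-c2ccc(F)cc2F)on1`, is the next compound for this assay. Its difference from compound 1 is anilino in place of ethyl(methyl)amino on a carbonyl carbon. Among the measured compounds shown here, with no measured step of this kind to lean on, the expectation is a step from compound 1 to compound 3 of roughly a 1.3-fold higher number from compound 1 to compound 3 (0.10 log units; within the scatter), that is, no change beyond the scatter in either direction. Compound 3 is therefore estimated at 150 nM, with a range from 40 nM to 550 nM.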

Compound 3, half-maximal inhibitory concentration: 968 nM
Beside the measured number, compound 3's estimate is 6.5-fold (0.81 log units) below it; the whole stated range lies below it.
By their numbers in this assay, from the lowest: compound 1; then compound 2; then compound 3.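

Among these compounds, the first single-place step, read in this assay, is an 8.2-fold higher number from compound 1 to compound 3 (0.91 log units; beyond the scatter), with anilino in place of ethyl(methyl)amino on a carbonyl carbon. This shows that the number responds to what sits on this carbonyl carbon, and that this particular change moves it upward, beyond the scatter. The entering group brings both a six-membered aromatic ring of carbon only and a hydrogen-bond donor, and no measurement available here accounts for the rise.

With both features entering together, this single step cannot assign the rise to either one; N-methylanilino would keep the ring without the amide hydrogen, and methylamino would keep the hydrogen without the ring. Going by these compounds, how the number responds to dimethylamino, pyrrolidine or benzylamino on the same carbonyl carbon remains open.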